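Ring methyl removal on the saturated-chain analogue

This account rests on a few compounds, and the source may have more. Where it says the series, first, only, none or still open, it means among the compounds named here.

Measured compounds:
- compound 1 `CC/C=C\C/C=C\C/C=C\CCCCCCCc1cc(=O)c2c(O)c(C)c(O)c(C)c2o1`: 6790 nM
- compound 2 `CC/C=C\C/C=C\C/C=C\CCCCCCCc1cc(=O)c2c(O)c(C)c(O)cc2o1`: 6790 nM
- compound 3 `CCCCCCCCCCCCCCCc1cc(=O)c2c(O)c(C)c(O)c(C)c2o1`: only a limit is known for compound 3, > 87000 nM

In a functional assay on MDA-MB-231 cells (Homo sapiens) for antiproliferative activity, read by MTT assay (on this read-out lower numbers stand for stronger inhibition and higher numbers for weaker inhibition), compound 1 gives 6790 nM and compound 2 gives 6790 nM. The step between them, no change at the digits printed from compound 1 to compound 2 (within the scatter), goes with hydrogen in place of methyl on an aromatic carbon. For compound 3 only a limit is recorded, > 87000 nM; it sits at the limit of > 87000 nM in this assay, at which 1 of the 3 values shown sits. The step of an at least 12-fold higher number from compound 1 to compound 3 (1.10 log units; beyond the scatter) goes with a group of 8 heavy atoms (8 carbon; no ring) in place of a group of 10 heavy atoms (10 carbon; no ring), on a saturated chain carbon, seven bonds along the chain from an aromatic carbon, and it is large.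

Compound 4 `CCCCCCCCCCCCCCCc1cc(=O)c2c(O)cc(O)c(C)c2o1` is not yet measured. It differs from compound 3 by hydrogen in place of methyl on an aromatic carbon. This is the same kind of change as that from compound 1 to compound 2, but the surroundings differ: in compound 1 the methyl that leaves is ortho to a fused ring, ortho to a hydroxy group and para to a hydroxy group, whereas in compound 3 it is ortho to two hydroxy groups and para to a fused ring.

Because no change at the digits printed from compound 1 to compound 2 (within the scatter) lay within the scatter, the step from compound 3 to compound 4 is expected to be small as well, a step that the limit leaves unreadable from compound 3 to compound 4. Since compound 3 itself only reached a limit, compound 4 is expected to give a limit too in most runs; the estimate for compound 4 is 100000 nM, with a range from 40000 nM to 300000 nM.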

Compound 4, half-maximal inhibitory concentration: 6790 nM
Estimate against measurement, compound 4: 15-fold (1.17 log units) above, outside the stated range (below it).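

In this assay, hydrogen in place of methyl on an aromatic carbon goes with an at least 12-fold lower number from compound 3 to compound 4 (1.10 log units; beyond the scatter), so this change does not carry over with a single size from one core to the other: the same change on two cores in this assay, no change at the digits printed (within the scatter) from compound 1 to compound 2 and an at least 12-fold lower number (1.10 log units; beyond the scatter) from compound 3 to compound 4, at least 12-fold (1.10 log units) apart, beyond the scatter of two such steps

Compound 3 is recorded only as a limit, > 87000 nM, so this step has a known minimum size but no exact one.

The two steps differ in the chain and also in which ring methyl leaves, and a single pair on each core cannot separate those two differences or support a rule for the whole series.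

Still open, as far as these compounds go, is how the methyl ortho to two hydroxy groups behaves on the core of compound 1, and how the other ring methyl behaves on the core of compound 3. Also open, from the compounds shown here alone, is whether the same contrast would hold with a shorter chain or a chain carrying an amine or a carboxylic acid.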